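This account rests on a few compounds, and the source may have more. Where it says the series, first, only, none or still open, it means among the compounds named here.

Measured compounds:
compound 1 `O=C(CI)NCCCCNc1ncnc2c1ncn2[C@@H]1O[C@H](COP(=O)(O)OP(=O)(O)OP(=O)(O)O)[C@@H](O)[C@H]1O` — 0%
compound 2 `O=C(CI)NCCNc1ncnc2c1ncn2[C@@H]1O[C@H](COP(=O)(O)OP(=O)(O)OP(=O)(O)O)[C@@H](O)[C@H]1O` — 0%

In an assay on isolated protein for inhibition of hexokinase-1 (Rattus norvegicus), with a stated time of 6 h, tested at 10 mM (on this read-out higher numbers stand for more inhibition at the one concentration tested (going by the name of the read-out) and lower numbers for less inhibition), compound 1 gives 0% and compound 2 gives 0%. Compound 2 stands level with compound 1 at the digits shown, and the step of no change at the digits printed from compound 1 to compound 2 (within the scatter) lies within the scatter. Compound 3 `O=C(CI)NCCCCCCCNc1ncnc2c1ncn2[C@@H]1O[C@H](COP(=O)(O)OP(=O)(O)OP(=O)(O)O)[C@@H](O)[C@H]1O` differs from compound 2 by 5-(((iodomethyl)carbonyl)amino)pentyl in place of ((iodomethyl)carbonyl)amino on a saturated chain carbon, two bonds along the chain from a nitrogen on an aromatic ring. For the measured compounds named here, the only measured step bearing on this change is the one from compound 1 to compound 2, which showed nothing beyond the scatter, so for compound 3 a step of no change at the digits printed from compound 2 to compound 3 (within the scatter) is expected, none beyond the scatter. Compound 3 is estimated at 0%, in the range 0% to 10%.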

Compound 3, a percentage reported as inhibition, at one concentration (the size of the read-out at that concentration, not a potency): 20%
Compound 3: middle estimate off by 20 percentage points, on the low side, outside the stated range (above it).
By their numbers in this assay, from the lowest: compounds 1 and 2 (each within the scatter of the next); then compound 3.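

Placing 5-(((iodomethyl)carbonyl)amino)pentyl in place of ((iodomethyl)carbonyl)amino on this saturated chain carbon brings a number 20 percentage points higher from compound 2 to compound 3 (beyond the scatter) in this assay, the first change here to exceed the scatter. Placing 3-(((iodomethyl)carbonyl)amino)propyl in place of ((iodomethyl)carbonyl)amino, four bonds along the chain, brings a number 20 percentage points higher from compound 1 to compound 3 (beyond the scatter) as well, so the chain of compound 3 separates from both shorter chains, whereas those two could not be told apart. Nothing available here offers an explanation for this rise.

The compounds shown leave open whether a longer chain would raise the number further. They also leave open whether the chain of compound 3 would behave the same with an amine or a carboxylic acid in place of the ((iodomethyl)carbonyl)amino end.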